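The source may report more compounds than this note shows. Statements on the series, on what has been measured and on what is new or still open speak of the compounds shown alone.

Measured in an ADME assay on CCRF-CEM cells (Homo sapiens) for cytotoxicity; a lower number here means a stronger inhibitor, a higher number a weaker inhibitor:
- Compound 1 `Nc1ccn([C@@H]2S[C@H](CO)C=C2F)c(=O)n1`: > 100000 nM
- Compound 2 `Nc1ncnc2c1ncn2[C@@H]1S[C@H](CO)C=C1F`: > 100000 nM

Compound 2 gives > 100000 nM, and this is a limit of this assay, not a number. The same holds for the other measured compound: the limit of > 100000 nM in this assay, at which 2 of the 2 values shown sit. Going by the values given here, the data therefore show no measured step and no graded potency for either compound.

Compound 3 `Nc1nc(F)nc2c1ncn2[C@@H]1S[C@H](CO)C=C1F` takes fluoro in place of hydrogen on an aromatic carbon of compound 2, between two ring nitrogen atoms: fluoro in place of hydrogen on an aromatic carbon. Among the compounds with values here, with no measured step to guide the size, only a modest gain in inhibition is expected, and compound 3 may well remain at the limit. The expected change is an at least 1.4-fold lower number from compound 2 to compound 3 (0.15 log units; that floor lies within the scatter). Compound 3 is estimated at 70000 nM, with an expected range of 20000 nM to 150000 nM.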

Compound 3, half-maximal inhibitory concentration: 1100 nM
The estimate for compound 3 lay 64-fold (1.80 log units) above the measured number; measured number below the stated range.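

Going by these compounds alone, compound 3, at 1100 nM, is the first compound here to give a real number in this assay, so this position between two ring nitrogen atoms can change the read-out, which the earlier compounds could not show. Fluoro in place of hydrogen on this aromatic carbon gives an at least 90-fold lower number from compound 2 to compound 3 (1.95 log units; beyond the scatter), a large change from a single substitution. That step is only a floor, not a full size, because compound 2 sits at a limit of the assay and not at a number: the limit of > 100000 nM in this assay, at which 2 of the 3 values shown sit.

The compounds shown leave open whether the change depends on fluoro itself or whether chloro, an amine or a methyl group at this position would act the same way. They also leave open how far below the limit compound 2 would fall, and so the true size of the step.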